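This account rests on a few compounds, and the source may have more. Where it says the series, first, only, none or still open, it means among the compounds named here.

Measured in a functional assay on FM3A cells (Mus musculus) for antiproliferative activity; a higher number here means a weaker inhibitor, a lower number a stronger inhibitor:
- compound 1 `COc1cc(C(=O)c2sc(-c3ccc(I)cc3)cc2N)cc(OC)c1OC`: 420 nM
- compound 2 `COc1cc(C(=O)c2sc(-c3ccccc3)cc2N)cc(OC)c1OC`: 13 nM
- compound 3 `COc1cc(C(=O)c2sc(-c3ccccc3Cl)cc2N)cc(OC)c1OC`: 34 nM

Compound 3, at 34 nM, holds the middle place of the three in this assay. It lies close to the unsubstituted phenyl of compound 2, with a 2.6-fold higher number from compound 2 to compound 3 (0.42 log units; beyond the scatter), a modest step. It lies far from compound 1, with a 12-fold lower number from compound 1 to compound 3 (1.09 log units; beyond the scatter), a large step.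

Compound 4 `COc1cc(C(=O)c2sc(-c3ccc(F)cc3)cc2N)cc(OC)c1OC` is still unmeasured. It differs from compound 3 by one change: 4-fluorophenyl in place of 2-chlorophenyl on an aromatic carbon.

The nearest evidence is mixed. The step of a 32-fold lower number from compound 1 to compound 2 (1.51 log units; beyond the scatter) is large and shows that a 4-iodophenyl group can cost much in this series. However, no measured compound carries a fluoro group, so that step cannot simply be carried over. The modest step of a 2.6-fold higher number from compound 2 to compound 3 (0.42 log units; beyond the scatter) suggests that compound 4 may stay near compound 2 and compound 3, with only a small rise possible from compound 2.

The estimated step is a 1.1-fold lower number from compound 3 to compound 4 (0.05 log units; within the scatter), so little change is expected. For compound 4 the expected value is 30 nM, with an estimated range of 10 nM to 120 nM.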

Compound 4, half-maximal inhibitory concentration: 16 nM
Compound 4: the middle estimate sits 1.9-fold (0.27 log units) above what was measured; the range from low to high includes it.
By their numbers in this assay, from the lowest: compounds 2 and 4 (each within the scatter of the next); then compound 3; then compound 1.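

In this assay, the fluoro group of compound 4 cannot be told apart from the hydrogen of compound 2 (a 1.2-fold higher number from compound 2 to compound 4 (0.09 log units; within the scatter)), whereas fluoro in place of iodo gives a large step (a 26-fold lower number from compound 1 to compound 4 (1.42 log units; beyond the scatter)). The heavy cost of the 4-iodophenyl group in compound 1 therefore does not extend to every halogen on this phenyl ring. The 4-fluorophenyl group also gives a modest step from the 2-chlorophenyl group (a 2.1-fold lower number from compound 3 to compound 4 (0.33 log units; beyond the scatter)), but that swap alters both the halogen and its place on the ring, so the two contributions cannot be separated, and no measured data here explain any of these steps.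

The compounds shown leave open where 4-chlorophenyl or 4-bromophenyl would fall between compound 2 and compound 1. They also leave open how 2-fluorophenyl, or a phenyl ring carrying an amine or a carboxylic acid, would compare.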